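A Second Fluorine on the Shared Core

This account rests on a few compounds, and the source may have more. Where it says the series, first, only, none or still open, it means among the compounds named here.

Compound 1 `Fc1cccc(/C=C/c2ccccc2)c1` — 3100 nM
Compound 2 `Cc1ccc(/C=C/c2ccc(F)cc2)cc1` — 1300 nM
Compound 3 `Cc1ccc(/C=C/c2cccc(F)c2)cc1` — 800 nM

All three were measured in an assay on HepG2 cells for activation of nuclear factor erythroid 2-related factor 2 (Homo sapiens), read by a luciferase reporter, with a stated time of 5 h; a lower number here means that less compound is needed, a higher number that more compound is needed for the effect. Compound 3 stands at the lowest of the three numbers. For the measured compounds named here, its only directly comparable neighbour is compound 1, and the step of a 3.9-fold lower number from compound 1 to compound 3 (0.59 log units; beyond the scatter) lies beyond the scatter. Compound 2 gives 1300 nM, which sits within the scatter of compound 3, so the two cannot be ordered.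

Compound 4 `Cc1ccc(/C=C/c2ccc(F)c(F)c2)cc1` is the next structure, and it differs from compound 3 by fluoro in place of hydrogen on an aromatic carbon. Going by the values given here, no measured step concerns adding a fluoro group; the single step available, from compound 1 to compound 3, concerns a methyl group and does not bear on the present change. The values of compound 2 and compound 3 show only that shifting a single fluoro group within the ring leaves the number within the scatter.

Among the compounds with values here, with no relevant step to draw on, the expectation for compound 4 is a number close to that of compound 3, with no step beyond the scatter: the estimate is 650 nM, with a range from 250 nM to 2000 nM, which corresponds to an expected step of a 1.2-fold lower number from compound 3 to compound 4 (0.09 log units; within the scatter).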

Compound 4, half-maximal effective concentration: 2600 nM
The estimate for compound 4 lay 4.0-fold (0.60 log units) below the measured number; measured number outside the range, above it.
By their numbers in this assay, from the lowest: compounds 3, 2, 4 and 1 (each within the scatter of the next, the first and the last beyond it).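

In this assay, for the compounds shown here, a fluoro group placed on an aromatic carbon, ortho to the fluoro group already present and para to a group of 9 heavy atoms, gives the first measured step for adding fluoro (a 3.3-fold higher number from compound 3 to compound 4 (0.51 log units; beyond the scatter)), and that step lies beyond the scatter. Going by these compounds alone, the same added group, read from the compound that carries its single fluoro group elsewhere, gives a step within the scatter (a 2.0-fold higher number from compound 2 to compound 4 (0.30 log units; within the scatter)), so the change stands out from only one of its two starting points, and the series gives no general penalty for a second fluoro group. Nothing measured here accounts for this difference between the two steps or for the size of either one.

From the compounds shown here alone, it remains open whether a second fluoro group would give a similar step on the core of compound 1, which lacks the methyl group. Going by these compounds, it also remains open whether a chloro group, a methoxy group or an amine at this same place would follow the fluoro group or part from it.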